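Methoxycarbonyl to ethoxycarbonyl: the step to compound 4

The compounds below may be only part of what the source reports. "The series", "measured", "known", "first", "only" and "open" are said of these compounds alone.

Measured in a functional assay on Jurkat cells (Homo sapiens) for cytotoxicity, read by MTT assay, with a stated time of 72 h; a higher number here means a weaker inhibitor, a lower number a stronger inhibitor:
- compound 1 `COC(=O)c1sc2cc(OC)ccc2c1Nc1cc(OC)c(OC)c(OC)c1`: 1.7 nM
- compound 2 `COC(=O)c1sc2nc(C)ccc2c1Nc1cc(OC)c(OC)c(OC)c1`: 0.6 nM
- compound 3 `COC(=O)c1sc2ncccc2c1Nc1cc(OC)c(OC)c(OC)c1`: 1110 nM

Among these three, compound 3 has the highest number, 1110 nM, while the nearest, compound 1, gives 1.7 nM. The compound still to be measured in this assay is compound 4 `CCOC(=O)c1sc2ncccc2c1Nc1cc(OC)c(OC)c(OC)c1`. It differs from compound 3 by methyl in place of hydrogen on a saturated chain carbon bound to an oxygen next to a carbonyl group, so that methoxycarbonyl becomes ethoxycarbonyl.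

Among the compounds with values here, only one measured step offers any comparison: a 1900-fold higher number from compound 2 to compound 3 (3.27 log units; beyond the scatter). That large step concerns hydrogen in place of methyl on an aromatic carbon, which is a different place and the reverse exchange. Within the data shown here, it therefore gives neither a size nor a direction for the present change, and no measured compound carries ethoxycarbonyl. No step beyond the scatter is the central expectation, but the range stays wide in view of a 1900-fold higher number from compound 2 to compound 3 (3.27 log units; beyond the scatter). The estimate amounts to an expected 1.1-fold lower number from compound 3 to compound 4 (0.05 log units; within the scatter). For compound 4 the estimated value is 1000 nM, with an expected range from 200 nM to 5000 nM.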

Compound 4, half-maximal inhibitory concentration: 8450 nM
Estimate against measurement, compound 4: 8.5-fold (0.93 log units) below, and the stated range ends below it.
By their numbers in this assay, from the lowest: compound 2; then compound 1; then compound 3; then compound 4.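

In this assay, the ester position proves sensitive to a small change: methyl in place of hydrogen on a saturated chain carbon bound to an oxygen next to a carbonyl group, turning methoxycarbonyl into ethoxycarbonyl, gives a 7.6-fold higher number from compound 3 to compound 4 (0.88 log units; beyond the scatter). Within the data shown here, the earlier compounds all carried methoxycarbonyl, so they showed nothing about this position, and their one step, a 1900-fold higher number from compound 2 to compound 3 (3.27 log units; beyond the scatter), concerned an aromatic carbon; the new step shows that the ester can also move the number beyond the scatter, though by less than that earlier step. No measurement at hand explains the change at the ester.

The compounds shown leave open whether ethoxycarbonyl would have a similar effect on the much lower numbers of compound 1 and compound 2, since this step has been read only on the core of compound 3. They also leave open how a longer chain such as propoxycarbonyl, or a carboxylic acid or an amide in place of the ester, would read in this assay.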